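Adding Chlorine to the Core of Compound 1

The compounds below may be only part of what the source reports. "The series", "measured", "known", "first", "only" and "open" are said of these compounds alone.

Compound 1 `CC/C(=C(/c1ccc(/C=C/C(=O)O)cc1)c1ccc2[nH]ncc2c1)c1ccccc1` gives 7.2 nM in a functional assay on MCF7 cells (Homo sapiens) for cytotoxicity, read by CellTiter-Glo, with a stated time of 5 days; a lower number here means a stronger inhibitor, a higher number a weaker inhibitor.
Compound 2 `O=C(O)/C=C/c1ccc(/C(=C(\c2ccccc2)C2CCC2)c2ccc3[nH]ncc3c2)cc1` gives 1.4 nM in this assay.

Among these two numbers compound 1 stands highest, meaning it is the weaker inhibitor of the pair; its only neighbour is compound 2, reached by a 5.1-fold lower number from compound 1 to compound 2 (0.71 log units; beyond the scatter) through cyclobutyl in place of ethyl on the chain. Compound 3 `CC/C(=C(/c1ccc(/C=C/C(=O)O)cc1)c1cc(Cl)c2[nH]ncc2c1)c1ccccc1` changes compound 1 at a different spot: chloro in place of hydrogen on an aromatic carbon, which cut one bond further out reads 1H-indazol-5-yl to 7-chloro-1H-indazol-5-yl. Among the measured compounds shown here, no measured step touches this part of the shared core, so the one known step, which alters the chain substituent, offers no direct guide. Lacking such a precedent, the expectation for compound 3 in this assay is a step of about a 1.0-fold lower number from compound 1 to compound 3 (0.01 log units; within the scatter), that is, nothing beyond the scatter in either direction. Compound 3 is therefore estimated at 7 nM, within a range from 2.5 nM to 20 nM.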

Compound 3, half-maximal inhibitory concentration: 56 nM
Beside the measured number, compound 3's estimate is 8.0-fold (0.90 log units) below it; the measured number lies above the stated range.
By their numbers in this assay, from the lowest: compound 2; then compound 1; then compound 3.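

In this assay, chloro in place of hydrogen on an aromatic carbon of the shared core gives a 7.8-fold higher number from compound 1 to compound 3 (0.89 log units; beyond the scatter), so compound 3 is a weaker inhibitor than its parent. Among the compounds shown here, until now the only known step was on the chain, and it lowered the number; this one shows that the core is not a neutral place to add a group, since a single chlorine atom on it moves the number the other way, beyond the scatter. Nothing measured here explains why the chlorine costs activity at this spot.

The compounds shown leave open whether the loss belongs to chloro alone or would also come with fluoro, methyl or methoxy in the same place. They also leave open whether 7-chloro-1H-indazol-5-yl would cost as much alongside the cyclobutyl of compound 2.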